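The compounds below may be only part of what the source reports. "The series", "measured", "known", "first", "only" and "open" are said of these compounds alone.

Compound 1, `COn1c(-c2ccc(C)cc2)c(C=O)c2cc(C#N)c(C#N)cc21`, carries a formyl group on the shared core, and in an assay on isolated protein for inhibition of Amine oxidase [flavin-containing] A (Homo sapiens), read by fluorescence and spectrophotometry, with a stated time of 20 min (on this read-out lower numbers stand for stronger inhibition and higher numbers for weaker inhibition), compound 1 gives 405 nM. Compound 2, `COn1c(-c2ccc(C)cc2)c(CO)c2cc(C#N)c(C#N)cc21`, has a hydroxymethyl group in its place, and in this assay compound 2 gives 5120 nM. This single exchange, hydroxymethyl in place of formyl on an aromatic carbon, gives a 13-fold higher number from compound 1 to compound 2 (1.10 log units; beyond the scatter).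

Compound 3, `COn1c(-c2ccccc2)c(Br)c2cc(C#N)c(C#N)cc21`, carries a bromo group at that position and a plain phenyl ring. In this assay compound 3 gives only a limit, > 100000 nM, and no number; that is, compound 3 sits at the limit of > 100000 nM in this assay, at which 1 of the 3 values shown sits.

Compound 4, `COn1c(-c2ccc(C)cc2)c(Br)c2cc(C#N)c(C#N)cc21`, differs from compound 3 in one place: methyl in place of hydrogen on an aromatic carbon, a methyl in place of hydrogen on an aromatic carbon, so that the phenyl becomes a 4-methylphenyl. Going by the values given here, none of the measured steps covers this change; the only measured step, the one from compound 1 to compound 2, concerns a different position, and compound 3 itself gives no number to build on. With compound 3 at the limit and the change being small, compound 4 is expected to give a value near 100000 nM, with a likely range from 20000 nM to 500000 nM. The step this estimate implies, a number no higher from compound 3 to compound 4 (the limit leaves the size open), is expected to be none beyond the scatter, and compound 4 may well again be reported only as a limit.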

Compound 4, half-maximal inhibitory concentration: > 100000 nM
Compound 4 gave a limit, no number (the forecaster's own chance of this, stated with the estimate: 60%); the middle value sits exactly at the limit.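

With the 4-methylphenyl ring held constant, the bromo group can now be compared directly with the two other groups at this position, and in this assay it shows an at least 240-fold higher number from compound 1 to compound 4 (2.39 log units; beyond the scatter) and an at least 19-fold higher number from compound 2 to compound 4 (1.29 log units; beyond the scatter). Among these three compounds, the formyl group of compound 1 therefore gives the strongest inhibition, and every gap between them lies beyond the scatter, although the gaps to compound 4 are minimum sizes. Compound 3 and compound 4 are both limits rather than numbers, so the step between them cannot be read, and adding the methyl group leaves the bromo pair at the same ceiling: the limit of > 100000 nM in this assay, at which 2 of the 4 values shown sit.

As far as these compounds go, the size of any effect of that methyl group remains unknown, and it could only be read from a pair in which both compounds give a number, such as compound 1 and its plain phenyl counterpart. From the compounds shown here alone, it also remains open whether an amine or a carboxylic acid at this position would give a number closer to that of compound 1 or would also reach the limit.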